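Replacing ethyl(methyl)amino with methyl in the cyano series

A few compounds are considered here, and "the series" means these few. Any claim that something is new, unique, unknown or untested is made for them only; others in the source may bear on it.

Measured so far in a functional assay on the whole organism with Rattus norvegicus as the target; on this read-out lower numbers stand for an effect already at smaller amounts and higher numbers for an effect only at larger amounts of compound
compound 1 `CCOC(=O)C(=O)Nc1cccc(N)c1C#N` gives 0.07 mg/kg
compound 2 `CCOC(=O)C(=O)Nc1cccc(N(C)CC)c1C#N` gives 0.5 mg/kg

Within the data shown here, compound 2 holds the higher of the two numbers, 0.5 mg/kg, and compound 1 is its only measured neighbour. The next compound is compound 3 `CCOC(=O)C(=O)Nc1cccc(C)c1C#N`, not yet measured, which has methyl in place of ethyl(methyl)amino on an aromatic carbon, ortho to a cyano group (methyl in place of ethyl(methyl)amino on an aromatic carbon). Among the measured compounds shown here, one measured step bears on this place: a 7.1-fold higher number from compound 1 to compound 2 (0.85 log units; beyond the scatter), with ethyl(methyl)amino in place of amino. For the measured compounds named here, it shows that this place can move the number, but no compound with methyl there has been measured, so it serves only as a rough bound on size. In this assay a small move toward a lower number is expected, not clearly beyond the scatter. The expected change is a 1.7-fold lower number from compound 2 to compound 3 (0.22 log units; within the scatter). For compound 3 the estimate is 0.3 mg/kg, with an expected range of 0.08 mg/kg to 1.2 mg/kg.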

Compound 3, dose for half-maximal effect: 4.6 mg/kg
Estimate against measurement, compound 3: 15-fold (1.19 log units) below, and the stated range ends below it.
By their numbers in this assay, from the lowest: compound 1; then compound 2; then compound 3.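

On the aromatic carbon ortho to a cyano group, this assay separates methyl from both groups carrying nitrogen: methyl in place of ethyl(methyl)amino gives a 9.2-fold higher number from compound 2 to compound 3 (0.96 log units; beyond the scatter) and methyl in place of amino gives a 66-fold higher number from compound 1 to compound 3 (1.82 log units; beyond the scatter) as the widest step among these compounds. Among these compounds, the earlier step compared only two groups carrying nitrogen, whereas the order now runs amino, ethyl(methyl)amino, methyl, with every step beyond the scatter. Nothing available explains this order.

With only these three groups, the presence of nitrogen at this place cannot be separated from the other differences between them. A methylamino or dimethylamino group would show how the number changes between amino and ethyl(methyl)amino, while an ethyl or methoxy group would test whether a different group without nitrogen stands as high as methyl.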